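Shifting sulfur and oxygen in the side group of compound 3

A few compounds are considered here, and "the series" means these few. Any claim that something is new, unique, unknown or untested is made for them only; others in the source may bear on it.

Compound 1, `Cc1nc(S(C)(=O)=O)ccc1Oc1ncnc(OC2CCN(C(=O)OC(C)C)CC2)c1F`: 77%
Compound 2, `Cc1nc(S(C)(=O)=O)ccc1Oc1ncnc(OC2CCN(C(=O)OC3(C(F)(F)F)CCC3)CC2)c1F`: 82%
Compound 3, `Cc1nc(S(C)(=O)=O)ccc1Oc1ncnc(OC2CCN(C(=O)SC(C)C)CC2)c1F`: 81%

In a functional assay on isolated protein for inhibition of Glucose-dependent insulinotropic receptor (Rattus norvegicus), read by HTRF and cAMP accumulation (on this read-out higher numbers stand for larger maximal responses and lower numbers for smaller maximal responses), compound 3 gives 81%. On the numbers shown this is the second highest of the three values, although a number 1 percentage points lower from compound 2 to compound 3 (within the scatter) and a number 4 percentage points higher from compound 1 to compound 3 (within the scatter) are both within the scatter, so no real separation among the three compounds can be claimed.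

Compound 4, `Cc1nc(S(C)(=O)=O)ccc1Oc1ncnc(OC2CCN(C(=S)OC(C)C)CC2)c1F`, differs from compound 3 in this way: a group of 6 heavy atoms (4 carbon, 1 oxygen, 1 sulfur; no ring) in place of a group of 6 heavy atoms (4 carbon, 1 oxygen, 1 sulfur; no ring), on an amine nitrogen in a ring. The two have the same atoms, joined differently: the sulfur and the oxygen of the side group exchange their roles.

The measured steps that bear on this all concern the same side group on the ring nitrogen. The closest is a number 4 percentage points higher from compound 1 to compound 3 (within the scatter), an exchange of isopropoxy for isopropylsulfanyl, which stayed within the scatter. The larger change a number 5 percentage points higher from compound 1 to compound 2 (within the scatter) likewise stayed within the scatter, as did a number 1 percentage points lower from compound 2 to compound 3 (within the scatter). Every alteration of this side group so far has left the maximal response essentially unchanged, so for compound 4 the expected step is a number 1 percentage points lower from compound 3 to compound 4 (within the scatter), none beyond the scatter. Compound 4 is therefore estimated to give 80%, with an expected range from 70% to 90%.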

Compound 4, largest response reached (reported as efficacy), in percent of the reference or control that the assay uses: 47%
The estimate for compound 4 lay 33 percentage points above the measured number, and the stated range ends above it.
By their numbers in this assay, from the lowest: compound 4; then compounds 1, 3 and 2 (each within the scatter of the next).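

The side group on the amine nitrogen in a ring proves less forgiving in this assay than compounds 1 to 3 suggested: swapping the sulfur and the oxygen gives a number 34 percentage points lower from compound 3 to compound 4 (beyond the scatter) even though the atoms stay the same. Replacing only the carbonyl oxygen with sulfur gives a number 30 percentage points lower from compound 1 to compound 4 (beyond the scatter) and the comparison with the bulkier ester group gives a number 35 percentage points lower from compound 2 to compound 4 (beyond the scatter) so compound 4 falls clearly apart from all three. Among these four compounds, sulfur is tolerated as the single-bonded link to isopropyl, while sulfur as the double-bonded atom goes with a much smaller maximal response. Nothing available here accounts for this drop.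

Going by these compounds, it remains open whether the double-bonded sulfur would lower the response equally with the 1-(trifluoromethyl)cyclobutyl group in place of isopropyl. On these data alone, it is also open how the response would change with sulfur in both places, as in a dithiocarbamate, or with an amine nitrogen in place of the single-bonded atom, as in a urea.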